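From pyrrolidin-3-yl to benzyl on an aromatic nitrogen

The compounds below may be only part of what the source reports. "The series", "measured", "known", "first", "only" and "open" are said of these compounds alone.

- Compound 1 `CC(C)Cn1nc(C(=O)N[C@H]2COc3ccccc3N(C)C2=S)nc1Cc1ccccc1`: 1230 nM
- Compound 2 `CN1C(=S)[C@@H](NC(=O)c2nc(Cc3ccccc3)n(C3CCOC3)n2)COc2ccccc21`: 1580 nM
- Compound 3 `CN1C(=S)[C@@H](NC(=O)c2nc(Cc3ccccc3)n(C3CCNC3)n2)COc2ccccc21`: 1070 nM

All three values come from a functional assay on HT-29 cells (Homo sapiens) for inhibition, read by luminescence and CellTiter-Glo, with a stated time of 24 h; on this read-out higher numbers stand for an effect only at larger amounts of compound and lower numbers for an effect already at smaller amounts. The data show a 1.1-fold lower number from compound 1 to compound 3 (0.06 log units; within the scatter) and a 1.5-fold lower number from compound 2 to compound 3 (0.17 log units; within the scatter), so compound 3 cannot be told apart from the other two compounds.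

The next compound, compound 4 `CN1C(=S)[C@@H](NC(=O)c2nc(Cc3ccccc3)n(Cc3ccccc3)n2)COc2ccccc21`, keeps the shared core and has benzyl in place of pyrrolidin-3-yl on an aromatic nitrogen.

The measured steps at this same nitrogen are the best guide. They are the two above and a 1.3-fold higher number from compound 1 to compound 2 (0.11 log units; within the scatter). Since all of these stay small, no step beyond the scatter is expected in this assay. Among the measured compounds shown here, none of the measured compounds carries an aromatic ring at this nitrogen, however, so the data leave benzyl itself untested and the range must stay fairly wide.

The expected change is a 1.2-fold higher number from compound 3 to compound 4 (0.08 log units; within the scatter). For compound 4 the estimated value is 1300 nM, with an expected range of 650 nM to 2600 nM.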

Compound 4, half-maximal effective concentration: 414 nM
Estimate against measurement, compound 4: 3.1-fold (0.50 log units) above, outside the stated range (below it).
By their numbers in this assay, from the lowest: compound 4; then compounds 3, 1 and 2 (each within the scatter of the next).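

In this assay, among the compounds shown here, the group on this aromatic nitrogen can matter after all: with benzyl there is a 2.6-fold lower number from compound 3 to compound 4 (0.41 log units; beyond the scatter) and also a 3.8-fold lower number from compound 2 to compound 4 (0.58 log units; beyond the scatter), both beyond the scatter, unlike any step among the earlier compounds. Putting phenyl in place of isopropyl on the saturated chain carbon bound to that nitrogen gives a 3.0-fold lower number from compound 1 to compound 4 (0.47 log units; beyond the scatter) as well, so a carbon-only group does not by itself bring the change, since the isobutyl of compound 1 is also carbon only. No data at hand explain why benzyl goes with the lower number.

The compounds shown leave open whether the ring must be aromatic, which cyclohexylmethyl, a saturated ring on the same one-carbon link, would test. They also leave open how phenylethyl, with its longer chain, would compare with benzyl.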